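The compounds below may be only part of what the source reports. "The series", "measured", "known", "first", "only" and "open" are said of these compounds alone.

Measured in a physicochemical assay for solubility; on this read-out lower numbers stand for lower solubility and higher numbers for higher solubility:
Compound 1 `O=C1CC(c2cc(F)c(F)c(F)c2)Oc2cc(O)cc(O)c21` gives 500000 nM.
Compound 2 `O=C1CC(c2cc(O)c(O)c(O)c2)Oc2cc(O)cc(O)c21` gives 63000 nM.
Compound 3 `O=C1CC(c2ccc(F)cc2)Oc2cc(O)cc(O)c21` gives 1000000 nM.

Among these three numbers compound 1 stands second highest. Its nearest neighbour is compound 3, whose higher number lies within the usual scatter of repeated measurements, so the two cannot be told apart. Compound 2 stands furthest away, with a lower number that lies beyond the scatter.

Compound 4 `O=C1CC(c2ccc(F)c(F)c2)Oc2cc(O)cc(O)c21` has not been measured. It differs from compound 1 in one place: hydrogen in place of fluoro on an aromatic carbon. The fluoro group that leaves sits ortho to a fluoro group and meta to a fluoro group, and those groups stay. Among the measured compounds shown here, no pair of measured compounds differs in one place alone, so there is no measured step to lean on; what can be said is that compound 1 and compound 3 sit within the scatter of each other in this assay. The step in this assay is therefore expected to be small, if anything towards a higher number, and not beyond the scatter: a 1.4-fold higher number from compound 1 to compound 4 (0.15 log units; within the scatter) is the expected change. For compound 4 a value of 700000 nM is estimated, in a range from 350000 nM to 1400000 nM.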

Compound 4, solubility: 1000000 nM
Beside the measured number, compound 4's estimate is 1.4-fold (0.15 log units) below it; the range from low to high includes it.
By their numbers in this assay, from the lowest: compound 2; then compounds 1, 3 and 4 (each within the scatter of the next).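

In this assay hydrogen in place of fluoro on an aromatic carbon, ortho to a fluoro group and meta to a fluoro group, now gives a first single-place step: a 2.0-fold higher number from compound 1 to compound 4 (0.30 log units; within the scatter) shows that the two groups cannot be told apart at this position. The second step, fluoro in place of hydrogen on an aromatic carbon, gives no change at the digits printed from compound 3 to compound 4 (within the scatter) and so also stays inside the scatter. Thus both single-place steps through compound 4 are small in this read-out, and nothing measured here offers a reason for them.

The compounds shown leave open what a chloro, methoxy or amine group would do at this position. Among the compounds shown here, no single-place step yet links compound 2, with its hydroxy groups, to the fluoro compounds.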